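Quinolin-3-yl in place of dihydrobenzofuranyl: oral bioavailability

The compounds below may be only part of what the source reports. "The series", "measured", "known", "first", "only" and "open" are said of these compounds alone.

Compound 2 `O=C(O)CC(Cc1nc(CCCc2ccc3c(n2)NCCC3)no1)c1ccc2c(c1)OCC2` stands lowest of the two compounds measured in an in vivo ADME assay on the whole organism for pharmacokinetics, with Rattus norvegicus as the target, at a dose of 5 mg/kg by the intravenous route (on this read-out higher numbers stand for higher oral bioavailability and lower numbers for lower oral bioavailability), giving 63%, while compound 1 `COc1ccc(C(CC(=O)O)Cc2nc(CCCc3ccc4c(n3)NCCC4)no2)cn1` gives 100%. The change to compound 3 `O=C(O)CC(Cc1nc(CCCc2ccc3c(n2)NCCC3)no1)c1cnc2ccccc2c1` is a group of 10 heavy atoms (9 carbon, 1 nitrogen; one six-membered aromatic ring of carbon only, one six-membered aromatic ring with 1 hetero atom) in place of a group of 9 heavy atoms (8 carbon, 1 oxygen; one five-membered non-aromatic ring with 1 hetero atom, one six-membered aromatic ring of carbon only), on a saturated chain carbon bound to two saturated chain carbons. Among the measured compounds shown here, the one measured step at this place, a number 37 percentage points lower from compound 1 to compound 2 (beyond the scatter), went from a six-membered aromatic ring with one hetero atom to a carbon-only bicycle; compound 3 returns an aromatic ring with one hetero atom, so a moderate rise is expected, a number 15 percentage points higher from compound 2 to compound 3 (beyond the scatter). For compound 3 the estimate in this assay is 78%, within 50% to 100%.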

Compound 3, oral bioavailability: 66%
The estimate for compound 3 lay 12 percentage points above the measured number; the range from low to high includes it.
By their numbers in this assay, from the lowest: compounds 2 and 3 (each within the scatter of the next); then compound 1.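

Quinolin-3-yl at this saturated chain carbon reads the same as the group it replaces in this assay, with a number 3 percentage points higher from compound 2 to compound 3 (within the scatter). Set against 6-methoxypyridin-3-yl, it gives a number 34 percentage points lower from compound 1 to compound 3 (beyond the scatter), so a six-membered aromatic ring with one hetero atom does not by itself match compound 1 among these three compounds. Nothing shown here explains these numbers.

Still open, from the compounds shown here alone, is whether the methoxy group or the ring nitrogen of 6-methoxypyridin-3-yl goes with the high number of compound 1. Unsubstituted pyridin-3-yl and 4-methoxyphenyl at this place would separate the two.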